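This account rests on a few compounds, and the source may have more. Where it says the series, first, only, none or still open, it means among the compounds named here.

Of the compounds shown here, three built on the same core have been tested so far: compound 1 `CN(C(=O)NC(=O)c1cccc(C(F)(F)F)c1)c1nc(C(F)(F)F)c(C(=O)N/N=C/c2cccc(C(F)(F)F)c2)s1`, compound 2 `CN(C(=O)NC(=O)c1ccc(Cl)c(Cl)c1)c1nc(C(F)(F)F)c(C(=O)N/N=C/c2ccc([N+](=O)[O-])cc2)s1` and compound 3 `CN(C(=O)NC(=O)c1ccccc1F)c1nc(C(F)(F)F)c(C(=O)N/N=C/c2ccccc2C(F)(F)F)s1`. In a functional assay on MCF7 cells (Homo sapiens) for inhibition, read by MTT assay, with a stated time of 72 h (on this read-out higher numbers stand for weaker inhibition and lower numbers for stronger inhibition), compound 1 gives 3.7 ug/mL, compound 2 gives 6.74 ug/mL and compound 3 gives 12.2 ug/mL. Within the data shown here, the number for compound 2 lies between those of compound 1 and compound 3, but each of those two neighbours is within the usual scatter of compound 2, so on these three results no compound can be set apart from the others.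

Compound 4 `CN(C(=O)NC(=O)c1ccc([N+](=O)[O-])cc1)c1nc(C(F)(F)F)c(C(=O)N/N=C/c2ccc([N+](=O)[O-])cc2)s1` has not yet been measured. It differs from compound 2 in one place: 4-nitrophenyl in place of 3,4-dichlorophenyl on a carbonyl carbon. Among the measured compounds shown here, no pair of measured compounds differs in just one place, so there is no measured step to lean on. Given that the three known values sit so close together, compound 4 is expected to stay near compound 2 in this assay, with a step of a 1.0-fold higher number from compound 2 to compound 4 (0.02 log units; within the scatter) that is not expected to go beyond the scatter in either direction. The estimate for compound 4 is 7 ug/mL, with a range from 3 ug/mL to 16 ug/mL.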

Compound 4, half-maximal inhibitory concentration: 9.24 ug/mL
Beside the measured number, compound 4's estimate is 1.3-fold (0.12 log units) below it; measured number inside the range.
By their numbers in this assay, from the lowest: compounds 1, 2, 4 and 3 (each within the scatter of the next, the first and the last beyond it).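

In this assay, putting 4-nitrophenyl in place of 3,4-dichlorophenyl on this carbonyl carbon gives a 1.4-fold higher number from compound 2 to compound 4 (0.14 log units; within the scatter). Among these compounds, this is the first comparison in which only one place changes, so the rest of the molecule cannot account for the difference. For this pair, the two aromatic groups cannot be told apart, even though they carry different atoms, and nothing measured here offers an explanation.

The compounds shown leave open whether a group of another kind on this carbonyl carbon, such as a simple alkyl chain or a phenyl ring carrying an amine or a carboxylic acid, would move the number beyond the scatter. They also leave open how much the aromatic group at the other end of the molecule matters when it alone is changed.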